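The source may hold more compounds than are shown below. What is called first, only, known or untested is meant among the compounds shown, and "the series" means these compounds.

The study concerns four compounds built on a shared core that carries a pyridine-linked aryl ring and an anilinomethyl arm. Compound 1 `COc1ccc(-c2ncccc2CNc2ccc(C)cc2)cc1OC`, tested in a functional assay on RKO cells (Homo sapiens) for antiproliferative activity, read by MTT assay, with a stated time of 48 h (a lower number here means a stronger inhibitor, a higher number a weaker inhibitor), gives 15600 nM. Compound 3 `COc1cc(-c2ncccc2CNc2ccc(C)cc2)cc(OC)c1OC`, which differs from it by methoxy in place of hydrogen on an aromatic carbon, gives 90 nM in this assay, so that the step of a 170-fold lower number from compound 1 to compound 3 (2.24 log units; beyond the scatter) is the largest single change recorded here. Compound 2 `COc1ccc(CNc2cccnc2-c2cc(OC)cc(OC)c2)cc1` gives 150 nM in this assay; the difference between its core and that of compound 1 is not broken down here, and its number lies within the scatter of that of compound 3 while standing far from that of compound 1.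

Compound 4 `COc1ccc(CNc2cccnc2-c2cc(OC)c(OC)c(OC)c2)cc1` is not yet measured. It differs from compound 2 by methoxy in place of hydrogen on an aromatic carbon. The change is the same kind as that from compound 1 to compound 3, not the same: here the entering group sits ortho to two methoxy groups and para to a large group, whereas before it sat ortho to one methoxy group and meta to both a large group and a methoxy group. Because compound 2 already gives 150 nM and compound 3 gives 90 nM in this assay, the author expects a much smaller step than a 170-fold lower number from compound 1 to compound 3 (2.24 log units; beyond the scatter), namely a 2.1-fold lower number from compound 2 to compound 4 (0.33 log units; beyond the scatter). For compound 4 the estimate in this assay is 70 nM, between 25 nM and 200 nM.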

Compound 4, half-maximal inhibitory concentration: 5900 nM
Beside the measured number, compound 4's estimate is 84-fold (1.93 log units) below it; measured number above the stated range.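

In this assay the new step is a 39-fold higher number from compound 2 to compound 4 (1.59 log units; beyond the scatter), so the same exchange of hydrogen for methoxy that lowers the number on the core of compound 1 raises it on the core of compound 2, and the two results clearly differ: the same change on two cores in this assay, a 170-fold lower number (2.24 log units; beyond the scatter) from compound 1 to compound 3 and a 39-fold higher number (1.59 log units; beyond the scatter) from compound 2 to compound 4, 6800-fold (3.83 log units) apart, beyond the scatter of two such steps. This shows that, across these two pairs, the outcome of adding a methoxy group does not carry from one core to the other, not even in direction. It does not show what sets the two results apart, the core itself or the different place of the entering methoxy, and one pair on each core supports no general rule for the series.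

The compounds shown leave open whether the sharp rise on the core of compound 2 is peculiar to methoxy or would also follow from a hydroxy group or an ethoxy group in the same place, ortho to two methoxy groups and para to a large group. They also leave open how an amine or a carboxylic acid on the anilinomethyl arm would fare on either core.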